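Removing a dimethylamino group from a carbamate inhibitor

This account rests on a few compounds, and the source may have more. Where it says the series, first, only, none or still open, it means among the compounds named here.

Compound 1, `CCCCCCCCOc1ccc(NC(=O)Oc2ccccc2F)cc1`: 19 nM in an assay on H4 cells for inhibition of Fatty-acid amide hydrolase 1 (Homo sapiens); on this read-out lower numbers stand for stronger inhibition and higher numbers for weaker inhibition
Compound 2, `CCCCCCCCCCCCOc1ccc(NC(=O)Oc2ccccc2F)cc1`: 13 nM in this assay
Compound 3, `CCCCOc1ccc(C(CC)NC(=O)Oc2cccc(N(C)C)c2)cc1`: 54 nM in this assay

Compound 3 has the highest number of the three, so on this read-out it is the weakest inhibitor shown. Among the compounds with values here, the only single-place step among the measured compounds is a 1.5-fold lower number from compound 1 to compound 2 (0.16 log units; within the scatter); it concerns the alkyl chain on the ether oxygen and tells nothing about the carbamate aryl ring.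

Compound 4, `CCCCOc1ccc(C(CC)NC(=O)Oc2ccccc2)cc1`, differs from compound 3 in exactly one place: hydrogen in place of dimethylamino on an aromatic carbon. No measured pair alters this ring, so no shown step bears directly on the change. Compounds 1 and 2 carry a fluorine on their carbamate ring and a different amine part, so they give no clean comparison either. With no evidence pointing either way, the expectation is a shift of modest size in this assay, more likely toward a higher number than a lower one, but possibly within the scatter. This amounts to an expected 1.5-fold higher number from compound 3 to compound 4 (0.17 log units; within the scatter). Compound 4 is therefore estimated at 80 nM, within a range from 25 nM to 250 nM.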

Compound 4, half-maximal inhibitory concentration: 12 nM
Beside the measured number, compound 4's estimate is 6.7-fold (0.82 log units) above it; measured number outside the range, below it.
By their numbers in this assay, from the lowest: compounds 4, 2 and 1 (each within the scatter of the next); then compound 3.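

In this assay, within the data shown here, replacing the dimethylamino group on the carbamate's aromatic ring with hydrogen gives a 4.5-fold lower number from compound 3 to compound 4 (0.65 log units; beyond the scatter), a change beyond the scatter and the first measured pair that isolates this ring. It shows that, at this aromatic carbon meta to a large group, the dimethylamino group is not needed for strong inhibition in this pair: the compound with no heavy atom there is the stronger inhibitor, even though three heavy atoms have been removed. Nothing shown explains why removing the group has this effect.

A single pair cannot separate a penalty specific to dimethylamino from a penalty for any group at this carbon, so a smaller or differently built substituent, such as methyl, methoxy or a plain amino group, at the same place would be needed to show how much room the position allows. Among these compounds, it also remains open whether the same step would appear with a different ether chain or amine part, since this comparison rests on only one shared core.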